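The compounds below may be only part of what the source reports. "The series", "measured", "known", "first", "only" and "open" are said of these compounds alone.

Measured so far in a functional assay on the whole organism with Mus musculus as the target, in the rotarod test; a higher number here means that more compound is needed for the effect, a lower number that less compound is needed:

- Compound 1 `NCC(=O)NCC(=O)Nc1ccc([N+](=O)[O-])cc1C(=O)c1ccccc1Cl`: 63.9 mg/kg
- Compound 2 `CN1CCN(CC(=O)NCC(=O)N(C)c2ccc(Cl)cc2C(=O)c2ccccc2Cl)CC1`: > 100 mg/kg (a limit)
- Compound 3 `CN(C(=O)CNC(=O)c1ccccc1)c1ccc(Cl)cc1C(=O)c1ccccc1Cl`: > 100 mg/kg (a limit)

Compound 2 has no exact value in this assay. Its result of > 100 mg/kg is a limit of the assay and not a number. The same holds for compound 3, whose result of > 100 mg/kg is also a limit. Together they make up (the limit of > 100 mg/kg in this assay, at which 2 of the 3 values shown sit). Only compound 1 has a true number, 63.9 mg/kg.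

The next compound is compound 4 `CN(C(=O)CNC(=O)CN1CCN(c2ccccc2)CC1)c1ccc(Cl)cc1C(=O)c1ccccc1Cl`. It keeps the frame of compound 2 and carries phenyl in place of methyl on an amine nitrogen in a ring, turning 4-methylpiperazin-1-yl into 4-phenylpiperazin-1-yl: phenyl in place of methyl on an amine nitrogen in a ring.

Among the compounds with values here, only one measured step bears on this change: a step that the two limits leave unreadable from compound 2 to compound 3. Phenyl enters there too, but on a carbonyl carbon, and the step has no readable size, so it offers nothing to carry over. With a limit as the starting point, no firm direction can be read either. The expected change is a step that the limit leaves unreadable from compound 2 to compound 4, and this is a loose expectation. The most likely outcome is that the new compound again reaches the limit of the assay. For compound 4 the estimated value is 110 mg/kg, with an expected range of 45 mg/kg to 250 mg/kg.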

Compound 4, dose for half-maximal effect: > 100 mg/kg
Compound 4: a limit, no number (the forecaster's own chance of this, stated with the estimate: 60%); the middle value does not contradict the limit.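

Compound 4 gives > 100 mg/kg in this assay, a limit of the assay and not a number. Compound 2 also has only a limit, and no step can be read between compound 2 and compound 4. The compounds shown leave open whether phenyl in place of methyl on the ring nitrogen changes the dose at all. The result joins the others here: the limit of > 100 mg/kg in this assay, at which 3 of the 4 values shown sit.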